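A few compounds are considered here, and "the series" means these few. Any claim that something is new, unique, unknown or untested is made for them only; others in the source may bear on it.

Working notes on the cyclopentene series with a benzyloxy-substituted aryl ring.

Compound 1 `O=C(O)c1cccc(C2=C(c3cc(Cl)ccc3OCc3ccccc3)CCC2)c1` is the reference; in an assay on isolated protein for inhibition of prostaglandin E2 receptor EP1 subtype (Homo sapiens) (a lower number here means a stronger inhibitor, a higher number a weaker inhibitor), compound 1 gives 5.01 nM, the lowest of the three numbers at hand. Compound 2 `O=C(O)c1ccnc(C2=C(c3cc(Cl)ccc3OCc3ccccc3)CCC2)n1` gives 158 nM in this assay, and compound 3 `O=C(O)c1cc(C2=C(c3cc(Cl)ccc3OCc3ccccc3)CCC2)cnn1` gives 39.8 nM. The measured steps all concern the ring that carries the carboxylic acid: a 32-fold higher number from compound 1 to compound 2 (1.50 log units; beyond the scatter), a 7.9-fold higher number from compound 1 to compound 3 (0.90 log units; beyond the scatter) and a 4.0-fold lower number from compound 2 to compound 3 (0.60 log units; beyond the scatter). Compound 1 thus stands clearly apart from both heteroaryl analogues, with compound 3 the nearer of the two.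

Compound 4 `CS(=O)(=O)c1ccc(OCc2ccccc2)c(C2=C(c3cccc(C(=O)O)c3)CCC2)c1` keeps the carboxyphenyl of compound 1 and changes the other aryl ring instead: methylsulfonyl in place of chloro on an aromatic carbon, on an aromatic carbon of a six-membered aromatic ring of carbon only, meta to a large group and para to the benzyloxy group. For the measured compounds named here, none of the measured steps touches this position, so no step at hand bears directly on the change; the three steps only show that the carboxyphenyl-bearing arrangement of compound 1 is the most favourable of those tried. With that arrangement retained, the change is expected to cost little, though the uncertainty is wide. Compound 4 is estimated at 12 nM, within 2.5 nM to 60 nM. The expected step is a 2.4-fold higher number from compound 1 to compound 4 (0.38 log units; beyond the scatter).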

Compound 4, half-maximal inhibitory concentration: 79.4 nM
Compound 4: middle estimate off by 6.6-fold (0.82 log units), on the low side; the whole stated range lies below it.
By their numbers in this assay, from the lowest: compound 1; then compounds 3, 4 and 2 (each within the scatter of the next, the first and the last beyond it).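

In this assay, for the compounds shown here, methylsulfonyl in place of chloro on this aromatic carbon, para to the benzyloxy group, gives a 16-fold higher number from compound 1 to compound 4 (1.20 log units; beyond the scatter), so this position, which no earlier step touched, does not tolerate this change without a clear penalty. The step is classed as large, as is a 32-fold higher number from compound 1 to compound 2 (1.50 log units; beyond the scatter), so large steps in this short series are not confined to the ring that carries the carboxylic acid. Methylsulfonyl brings more heavy atoms and more hydrogen-bond acceptors than chloro, but nothing at hand separates these differences or accounts for the step.

With only chloro and methylsulfonyl shown at this carbon, it remains open whether the higher number goes with the larger group or with its sulfonyl oxygens, a question that a methyl, a methoxy or a nitrile at the same place would help to settle. From the compounds shown here alone, it is also open whether methylsulfonyl would carry a step of similar size when paired with the 4-carboxypyrimidin-2-yl of compound 2 or the 6-carboxypyridazin-4-yl of compound 3.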